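Working notes: 3-nitrophenyl in place of 4-fluorophenyl

This account rests on a few compounds, and the source may have more. Where it says the series, first, only, none or still open, it means among the compounds named here.

Going by the values given here, in an ADME assay on cells (Epithelial cell, Homo sapiens) for antiproliferative activity, read by MTT assay, with a stated time of 48 h (on this read-out lower numbers stand for stronger inhibition and higher numbers for weaker inhibition), compound 1 `COC(=O)/C(=C/c1ccccc1)CN1C(=O)[C@@H](OC)[C@H]1c1ccc(F)cc1` gives 27900 nM, the only number so far. Compound 2 `CCOC(=O)/C(=C/c1ccccc1)CN1C(=O)[C@@H](OC)[C@H]1c1ccc(F)cc1` is recorded as "not toxic" (no number reported), an entry without a number. Compound 3 `CO[C@@H]1C(=O)N(C/C(C#N)=C/c2ccccc2)[C@@H]1c1ccc(Cl)cc1Cl` reads > 100000 nM, which is a limit of the assay and not a number.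

The next compound to be read is compound 4 `COC(=O)/C(=C/c1ccccc1)CN1C(=O)[C@@H](OC)[C@H]1c1cccc([N+](=O)[O-])c1`. It carries 3-nitrophenyl in place of 4-fluorophenyl on a saturated ring carbon of the four-membered non-aromatic ring: 3-nitrophenyl in place of 4-fluorophenyl on a saturated ring carbon. Among the compounds with values here, the series holds no measured step for a single change, so the size of this one cannot be read from the data. With compound 1 at 27900 nM as the only anchor, no shift beyond the usual scatter is expected in this assay, and no firm direction. The expected move is a 1.3-fold higher number from compound 1 to compound 4 (0.10 log units; within the scatter). The estimate for compound 4 is 35000 nM, with an expected range from 10000 nM to 90000 nM.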

Compound 4, half-maximal inhibitory concentration: "not toxic" (no number reported)
For compound 4 the study gives words and no number; there is nothing to compare the estimate with.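

No step can be read from compound 1 to compound 4, since compound 4 is recorded only in words, as not toxic. The compounds shown leave open how that entry relates to a number, the only mark being a limit and not a number: the limit of > 100000 nM in this assay, at which 1 of the 4 values shown sits.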